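The compounds below may be only part of what the source reports. "The series", "measured", "known", "first", "only" and "open" are said of these compounds alone.

Three compounds sharing one core differ only in the aryl group on a carbon with a double bond to nitrogen. In a functional assay on SW 1116 cells (Homo sapiens) for cytotoxicity, read by MTT assay, with a stated time of 48 h (a higher number here means a weaker inhibitor, a lower number a stronger inhibitor), compound 1 `COc1cccc(/C=N/NC(=O)CSc2nnc(-c3ccncc3)o2)c1` gives 16500 nM, compound 2 `O=C(CSc1nnc(-c2ccncc2)o1)N/N=C/c1ccccc1[N+](=O)[O-]` gives 30700 nM, and compound 3 `O=C(CSc1nnc(-c2ccncc2)o1)N/N=C/c1cc(Br)ccc1O` gives 8150 nM, the lowest of the three numbers. The steps of a 2.0-fold lower number from compound 1 to compound 3 (0.31 log units; beyond the scatter) and a 3.8-fold lower number from compound 2 to compound 3 (0.58 log units; beyond the scatter) show that swapping this aryl group moves the number modestly, while a 1.9-fold higher number from compound 1 to compound 2 (0.27 log units; within the scatter) stays within the scatter. Compound 4 `O=C(CSc1nnc(-c2ccncc2)o1)N/N=C/c1ccc(O)c(O)c1` carries 3,4-dihydroxyphenyl in place of 5-bromo-2-hydroxyphenyl on a carbon with a double bond to nitrogen. Because a 2.0-fold lower number from compound 1 to compound 3 (0.31 log units; beyond the scatter) and a 3.8-fold lower number from compound 2 to compound 3 (0.58 log units; beyond the scatter) are both only modest, a modest weakening is expected for compound 4, roughly a 1.5-fold higher number from compound 3 to compound 4 (0.17 log units; within the scatter). The estimate for compound 4 is 12000 nM, with a range from 5000 nM to 30000 nM.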

Compound 4, half-maximal inhibitory concentration: 1540 nM
For compound 4 the middle estimate is 7.8-fold (0.89 log units) above the measured one; measured number below the stated range.
By their numbers in this assay, from the lowest: compound 4; then compound 3; then compounds 1 and 2 (each within the scatter of the next).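

In this assay, the aryl group on this carbon matters more than the first three compounds suggested: 3,4-dihydroxyphenyl gives a 5.3-fold lower number from compound 3 to compound 4 (0.72 log units; beyond the scatter), with larger steps of an 11-fold lower number from compound 1 to compound 4 (1.03 log units; beyond the scatter) and a 20-fold lower number from compound 2 to compound 4 (1.30 log units; beyond the scatter). Even the step from the bromo compound changes more than one feature of the ring, so it cannot single out which feature matters. No measurement here explains the gain. Still open, going by these compounds, is whether 4-hydroxyphenyl or 3-hydroxyphenyl alone would match 3,4-dihydroxyphenyl, and how an amine or a carboxylic acid on the ring would compare.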